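Removing the propanoylamino group from compound 2

The source may hold more compounds than are shown below. What is called first, only, known or untested is meant among the compounds shown, and "the series" means these compounds.

Measured in a functional assay on A549 cells (Homo sapiens) for cytotoxicity, read by MTT assay, with a stated time of 4 days; on this read-out lower numbers stand for stronger inhibition and higher numbers for weaker inhibition:
compound 1 `COc1cc(C[C@H]2C(=O)OC[C@@H]2Cc2ccc(OC)c(OC)c2)ccc1NC(=O)c1ccccc1`: > 50000 nM
compound 2 `CCC(=O)Nc1ccc(C[C@H]2C(=O)OC[C@@H]2Cc2ccc(OC)c(OC)c2)cc1OC`: > 50000 nM
compound 3 `COc1cc(C[C@H]2C(=O)OC[C@@H]2Cc2ccc(OC)c(OC)c2)ccc1Nc1ccc(F)cc1`: > 50000 nM

Each of these entries is a limit of the assay and not a number. Compound 2 therefore has no measured value, only the limit > 50000 nM. The whole set gives the same picture: the limit of > 50000 nM in this assay, at which 3 of the 3 values shown sit.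

Compound 4 `COc1cccc(C[C@H]2C(=O)OC[C@@H]2Cc2ccc(OC)c(OC)c2)c1` is compound 2 without one group: hydrogen in place of propanoylamino on an aromatic carbon. Hydrogen stands in place of propanoylamino on an aromatic carbon, ortho to a methoxy group.

The closest evidence comes from changes at that same site, where the group that compound 4 loses is swapped for others. These are a step that the two limits leave unreadable from compound 1 to compound 2, a step that the two limits leave unreadable from compound 1 to compound 3 and a step that the two limits leave unreadable from compound 2 to compound 3. None of these steps has a readable size, so they offer no measured direction to carry over. All that can be expected in this assay is that removing the group leaves the compound weak, near the same limit. The estimated change is a number no higher from compound 2 to compound 4 (the limit leaves the size open), and no firm direction is expected for it. Another limit instead of a number is the likeliest report. For compound 4 the expected value is 50000 nM, with an estimated range of 20000 nM to 100000 nM.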

Compound 4, half-maximal inhibitory concentration: > 50000 nM
Compound 4: only a limit was reported; the forecaster's own chance of this, stated with the estimate: 80%; the middle value sits exactly at the limit.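

In this assay compound 4 gives > 50000 nM, which is a limit of the assay and not a number. Within the data shown here, no step linking compound 4 with compound 1, compound 2 or compound 3 can therefore be read. The whole set gives one picture: the limit of > 50000 nM in this assay, at which 4 of the 4 values shown sit.

These compounds leave open whether any group at this site changes cytotoxicity, and by how much.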